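This account rests on a few compounds, and the source may have more. Where it says the series, first, only, none or still open, it means among the compounds named here.

Compound 1 `C=C(Br)C(=O)Nc1ccc(/C=C2\SC(=O)N(CC)C2=O)cc1` gives 1400 nM in a functional assay on HeLa cells (Homo sapiens) for cytotoxicity, read by cell counting, with a stated time of 4 days (a higher number here means a weaker inhibitor, a lower number a stronger inhibitor), the lowest of the two numbers in hand. Compound 2 `CCN1C(=O)S/C(=C\c2ccc(N)cc2)C1=O` gives 108000 nM in this assay, and the step of a 77-fold higher number from compound 1 to compound 2 (1.89 log units; beyond the scatter) is the only measured one. Compound 3 `Nc1cccc(/C=C2\SC(=O)N(Cc3ccccc3)C2=O)c1` returns only a limit in this assay, > 250000 nM; see (the limit of > 250000 nM in this assay, at which 1 of the 3 values shown sits).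

Compound 4 `C=C(Br)C(=O)Nc1ccc(/C=C2\SC(=O)N(C)C2=O)cc1` differs from compound 1 by hydrogen in place of methyl on a saturated chain carbon bound to an amide-type nitrogen in a ring, read one bond further out as ethyl to methyl. Going by the values given here, no measured step touches this position; the single step in hand concerns the aromatic nitrogen, so nothing here argues for a change beyond the scatter. For compound 4 the expected step is no change at the digits printed from compound 1 to compound 4 (within the scatter). Compound 4 is therefore estimated at 1400 nM, with a range of 500 nM to 4000 nM.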

Compound 4, half-maximal inhibitory concentration: 870 nM
The estimate for compound 4 lay 1.6-fold (0.21 log units) above the measured number, within the range that was stated.
By their numbers in this assay, from the lowest: compounds 4 and 1 (each within the scatter of the next); then compound 2. At a limit, above all of these: compound 3.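

In this assay, going by these compounds alone, going from ethyl to methyl on the amide-type nitrogen in the ring gives a 1.6-fold lower number from compound 1 to compound 4 (0.21 log units; within the scatter) and is the first measured step at this position. With the (1-bromoethenyl)carbonyl group kept in place, ethyl and methyl cannot be told apart here. Nothing in hand gives a cause for this step.

Only these two groups are compared at this position with that group in place. From the compounds shown here alone, a longer chain such as butyl, or a chain ending in a carboxylic acid or an amine, remains open.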